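Adding a second methoxy to compound 3

A few compounds are considered here, and "the series" means these few. Any claim that something is new, unique, unknown or untested is made for them only; others in the source may bear on it.

Compound 1 `CC(Nc1ccccc1Oc1cccc(F)c1)=C1C(=O)CC(c2ccccc2)CC1=O`: 360 nM
Compound 2 `CC(Nc1ccccc1Oc1ccc(Cl)cc1)=C1C(=O)CC(c2ccccc2)CC1=O`: 260 nM
Compound 3 `COc1ccc(Oc2ccccc2NC(C)=C2C(=O)CC(c3ccccc3)CC2=O)cc1`: 83 nM

In a functional assay on HMEC-1 cells (Homo sapiens) for antiproliferative activity, read by cell counting, with a stated time of 4 days (a lower number here means a stronger inhibitor, a higher number a weaker inhibitor), compound 3 gives 83 nM, the lowest of the three numbers. Its lead over the other two lies beyond the scatter, as shown by a 3.1-fold lower number from compound 2 to compound 3 (0.50 log units; beyond the scatter) and a 4.3-fold lower number from compound 1 to compound 3 (0.64 log units; beyond the scatter). The remaining step, a 1.4-fold lower number from compound 1 to compound 2 (0.14 log units; within the scatter), stays within the scatter and gives no order.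

The next compound is compound 4 `COc1ccc(Oc2ccccc2NC(C)=C2C(=O)CC(c3ccccc3)CC2=O)cc1OC`, where 4-methoxyphenyl becomes 3,4-dimethoxyphenyl. The change is methoxy in place of hydrogen on an aromatic carbon, ortho to a methoxy group and meta to a large group.

Going by the values given here, no measured step makes this kind of change, so the evidence is indirect. The nearest steps are a 3.1-fold lower number from compound 2 to compound 3 (0.50 log units; beyond the scatter), with methoxy in place of chloro, and a 4.3-fold lower number from compound 1 to compound 3 (0.64 log units; beyond the scatter). Both are modest, and neither shows what a second methoxy would do. A step of about their size is therefore the most that is expected, in either direction, and the likeliest outcome is none beyond the scatter. The expected change is a 1.2-fold higher number from compound 3 to compound 4 (0.08 log units; within the scatter). For compound 4, the estimated value is 100 nM, within an expected range of 35 nM to 280 nM.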

Compound 4, half-maximal inhibitory concentration: 140 nM
Estimate against measurement, compound 4: 1.4-fold (0.15 log units) below, and the stated range covers the measured number.
By their numbers in this assay, from the lowest: compounds 3, 4, 2 and 1 (each within the scatter of the next, the first and the last beyond it).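

In this assay the methoxy in place of hydrogen, ortho to a methoxy group and meta to a large group, gives a 1.7-fold higher number from compound 3 to compound 4 (0.23 log units; within the scatter) and so shows that a second methoxy at this position leaves the number within the scatter of compound 3. The 3,4-dimethoxyphenyl group gives a 1.9-fold lower number from compound 2 to compound 4 (0.27 log units; within the scatter) against the 4-chlorophenyl group, which sets no order between them, while against the 3-fluorophenyl group it gives a 2.6-fold lower number from compound 1 to compound 4 (0.41 log units; beyond the scatter) and so keeps a separation from compound 1 that lies beyond the scatter, as the 4-methoxyphenyl group of compound 3 also does. Nothing measured here accounts for any of these steps.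

The compounds shown leave open whether this tolerance is particular to methoxy or extends to other groups at the same position, such as a hydroxyl, an ethoxy, an amine or a carboxylic acid. They also leave open how a second methoxy would read on the 3-fluorophenyl or 4-chlorophenyl groups, where a methoxy has not yet been paired with either halogen.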